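Removing the Amide Side Chain from Compound 1

The source may report more compounds than this note shows. Statements on the series, on what has been measured and on what is new or still open speak of the compounds shown alone.

Going by the values given here, compound 1 `CC[C@@H]1C(=O)N(C)c2cnc(-n3ccc4cc(C(=O)NCC(C)C)ccc43)nc2N1C1CCCC1` is the only compound here with a numerical result: in a functional assay on K562 cells (Homo sapiens) for antiproliferative activity, read by CCK-8 assay, with a stated time of 72 h (a lower number here means a stronger inhibitor of growth, a higher number a weaker inhibitor of growth), compound 1 gives 638 nM. Compound 2 `CCC1C(=O)N(C)c2cnc(Nc3ccc(S(N)(=O)=O)cc3)nc2N1c1ccn(C)n1`, which shares the core but carries different groups around it, was reported in this assay as "not active" (no number reported), with no number attached, so it offers no point of comparison for the size of any step. Compound 3 `CC[C@@H]1C(=O)N(C)c2cnc(-n3ccc4ccccc43)nc2N1C1CCCC1` is compound 1 with a single change: hydrogen in place of isobutylcarbamoyl on an aromatic carbon. The group that leaves, isobutylcarbamoyl, brings one hydrogen-bond donor and one hydrogen-bond acceptor; compound 3 keeps neither. Among the compounds with values here, no measured pair shows what this change does, so the direction and size of the step rest on expectation alone. Compound 3 is expected to be a somewhat weaker growth inhibitor than compound 1, with an estimated step of a 2.8-fold higher number from compound 1 to compound 3 (0.45 log units; beyond the scatter) in this assay. The estimated value for compound 3 is 1800 nM, within a range from 600 nM to 6000 nM.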

Compound 3, concentration for 50% growth inhibition: 6910 nM
Estimate against measurement, compound 3: 3.8-fold (0.58 log units) below; measured number above the stated range.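

Taking the isobutylcarbamoyl group off the aromatic carbon gives an 11-fold higher number from compound 1 to compound 3 (1.03 log units; beyond the scatter) in this assay and is the first measured change at this position. The step is large and lies beyond the scatter, so in this pair the group contributes substantially to the growth inhibition seen with compound 1. Compound 3 still gives a number, 6910 nM, so growth inhibition weakens without being lost when the group is absent, but nothing available explains why the step has this size.

Since the whole group leaves at once, this pair cannot separate the part played by the carbonyl and the amide hydrogen from that of the isobutyl chain. A methylcarbamoyl group, a longer chain on the amide or a carboxylic acid at this aromatic carbon could help to separate them.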